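The compounds below may be only part of what the source reports. "The series", "measured", "known", "first", "only" and "open" are said of these compounds alone.

Measured so far in an assay for binding affinity to Adrenergic receptor alpha-1 (Rattus norvegicus); on this read-out higher numbers stand for weaker inhibition and lower numbers for stronger inhibition: compound 1 `COc1cc2nc(N3CCN(C(=O)CCc4ccccc4)CC3)nc(N)c2cc1OC` gives 3.39 nM; compound 2 `COc1cc2nc(N3CCN(C(=O)COc4ccccc4)CC3)nc(N)c2cc1OC` gives 12.6 nM; compound 3 `COc1cc2nc(N3CCN(C(=O)/C=C/C(=O)c4ccccc4)CC3)nc(N)c2cc1OC` gives 87.1 nM.

Compound 3 stands at the highest number of the three, and each of its steps to the others lies beyond the scatter: a 26-fold higher number from compound 1 to compound 3 (1.41 log units; beyond the scatter) and a 6.9-fold higher number from compound 2 to compound 3 (0.84 log units; beyond the scatter). The group on the carbonyl carbon is the only place where the three differ, and the smaller step, a 3.7-fold higher number from compound 1 to compound 2 (0.57 log units; beyond the scatter), shows that even the exchange of one saturated-chain substituent for another there moves this assay by a modest amount.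

Compound 4 `COc1cc2nc(N3CCN(C(=O)c4ccc5ccccc5c4)CC3)nc(N)c2cc1OC` carries the change (naphthalen-2-yl in place of 2-benzoylethenyl on a carbonyl carbon). Within the data shown here, no measured step introduces an aromatic ring directly on the carbonyl carbon, so the pattern only says that the 2-benzoylethenyl group of compound 3 gave the weakest binding of the set and that every alternative tried there gave a lower number. On that basis the author expects compound 4 to return toward the numbers of compound 1 and compound 2, a step estimated at an 11-fold lower number from compound 3 to compound 4 (1.04 log units; beyond the scatter). Compound 4 is therefore estimated at 8 nM, with a range from 2 nM to 40 nM.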

Compound 4, half-maximal inhibitory concentration: 49 nM
Beside the measured number, compound 4's estimate is 6.1-fold (0.79 log units) below it, outside the stated range (above it).
By their numbers in this assay, from the lowest: compound 1; then compound 2; then compounds 4 and 3 (each within the scatter of the next).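

On the carbonyl carbon bound to the amide-type nitrogen in a ring, a 1.8-fold lower number from compound 3 to compound 4 (0.25 log units; within the scatter) separates 2-benzoylethenyl from naphthalen-2-yl in this assay and so shows that a group with its aromatic rings set directly on that carbon reads alike with 2-benzoylethenyl, even though naphthalen-2-yl has no double bond outside aromatic rings and no hydrogen-bond acceptor. Naphthalen-2-yl also stays apart from the two groups with a saturated chain, with a 3.9-fold higher number from compound 2 to compound 4 (0.59 log units; beyond the scatter) on the phenoxymethyl side and a 14-fold higher number from compound 1 to compound 4 (1.16 log units; beyond the scatter) on the phenethyl side, so the high numbers at this position are not confined to 2-benzoylethenyl. Nothing given here accounts for these differences.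

The compounds shown leave open whether a single phenyl group on the carbonyl carbon would read with naphthalen-2-yl or with phenethyl. They also leave open how a longer chain, or an amine or a carboxylic acid carried on the phenethyl group, would read in this assay at this position.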